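A Methyl on the Fused Ring of Compound 1

The source may report more compounds than this note shows. Statements on the series, on what has been measured and on what is new or still open speak of the compounds shown alone.

Measured so far in a functional assay on SW480 cells (Homo sapiens) for inhibition, read by luminescence and resazurin assay, with a stated time of 3 days; on this read-out lower numbers stand for stronger inhibition and higher numbers for weaker inhibition:
compound 1, `C=CCNc1nc(NCc2ccc(C(=O)Nc3ccc(F)cc3)cc2)c2ccccc2n1`: 11000 nM
compound 2, `CNc1nc2ccccc2c(NCc2ccc(NC(=O)c3ccc(F)cc3)cc2)c1C#N`: > 20000 nM
compound 3, `CN(C)c1nc(NCc2ccc(C(=O)N3CCC(C(=O)NCc4ccc(F)cc4)CC3)cc2)c2ccccc2n1`: 5500 nM

Two of these three compounds give a number in this assay. Compound 1 gives 11000 nM, the higher of the two numbers, while compound 3 gives 5500 nM, a value that lies within the scatter of compound 1, so neither can be called the stronger inhibitor. For compound 2 the assay reports only a limit, > 20000 nM, and this limit is the one described by the limit of > 20000 nM in this assay, at which 1 of the 3 values shown sits.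

Compound 4 `C=CCNc1nc(NCc2ccc(C(=O)Nc3ccc(F)cc3)cc2)c2cc(C)ccc2n1` has not yet been measured. It differs from compound 1 by methyl in place of hydrogen on an aromatic carbon. Going by the values given here, with no measured pair that differs in one place, there is no direct guide to the size of this step. A single methyl on the shared core is a small change, and in this assay the step from compound 1 to compound 4 is expected to stay within the scatter, perhaps leaning slightly toward a lower number. Compound 4 is therefore expected to give about 9000 nM, with a range from 4000 nM to 20000 nM. The expected step of a 1.2-fold lower number from compound 1 to compound 4 (0.09 log units; within the scatter) is thus estimated as no larger than the usual scatter.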

Compound 4, half-maximal inhibitory concentration: 10000 nM
Compound 4: the middle estimate sits 1.1-fold (0.05 log units) below what was measured; measured number inside the range.
By their numbers in this assay, from the lowest: compounds 3, 4 and 1 (each within the scatter of the next). At a limit, above all of these: compound 2.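

Compounds 1 and 4 form the first pair shown that differs in one place, so the size of a single step on the shared core can now be read. In this assay the pair gives a 1.1-fold lower number from compound 1 to compound 4 (0.04 log units; within the scatter) and so shows that methyl in place of hydrogen on this aromatic carbon of the fused system leaves the two compounds within the scatter of each other. Nothing measured here bears on why this step is so small.

From the compounds shown here alone, whether a methoxy group, a chlorine atom or an amine at this same carbon would also stay within the scatter remains open. Also open, going by these compounds, is whether a methyl here would give a similar step on a compound with a different side chain, such as compound 3.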